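A few compounds are considered here, and "the series" means these few. Any claim that something is new, unique, unknown or untested is made for them only; others in the source may bear on it.

Three members of this series have been run in a functional assay on the whole organism (strain Wistar albino) for inhibition, with Rattus norvegicus as the target, read by paw edema, with stated times of 30 min and 3 h, at a dose of 0.05 mmol/kg; a lower number here means less inhibition, a higher number more inhibition at the dose given (going by the name of the read-out). Compound 1 `COc1ccc([C@@H]2CC(c3cccc(O)c3)=NN2c2ccc(S(N)(=O)=O)cc2)cc1` gives 64.7%, compound 2 `Cc1ccc([C@@H]2CC(c3cccc(O)c3)=NN2c2ccc(S(N)(=O)=O)cc2)cc1` gives 64.7%, and compound 3 `NS(=O)(=O)c1ccc(N2N=C(c3cccc(O)c3)C[C@H]2c2ccccc2Cl)cc1` gives 32.6%. Compound 2 thus stands level with compound 1 at the digits shown, the two together the highest of the three numbers, with compound 3 well apart from both. Compound 4 `COc1ccc([C@@H]2CC(c3cccc(O)c3)=NN2c2ccc(S(N)(=O)=O)cc2)cc1OC` differs from compound 2 in one place: 3,4-dimethoxyphenyl in place of 4-methylphenyl on a saturated ring carbon. The step that bears on this most directly is no change at the digits printed from compound 1 to compound 2 (within the scatter), where 4-methoxyphenyl and 4-methylphenyl on the saturated ring carbon give the same number. The large drops a number 32.1 percentage points lower from compound 2 to compound 3 (beyond the scatter) and a number 32.1 percentage points lower from compound 1 to compound 3 (beyond the scatter) concern 2-chlorophenyl and are of another kind. Compound 4 is therefore expected to show at most a small step, a number 3.7 percentage points lower from compound 2 to compound 4 (within the scatter), within or near the scatter. Compound 4 is estimated at 61%, likely between 47% and 73%.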

Compound 4, a percentage reported as inhibition, in the whole organism at one dose (the size of the read-out at that dose, not a potency): 55.9%
Beside the measured number, compound 4's estimate is 5.1 percentage points above it; the measured number falls inside the stated range.
By their numbers in this assay, from the lowest: compound 3; then compounds 4, 1 and 2 (each within the scatter of the next).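

In this assay methoxy in place of hydrogen on an aromatic carbon stays within the scatter (a number 8.8 percentage points lower from compound 1 to compound 4 (within the scatter)), as does 3,4-dimethoxyphenyl in place of 4-methylphenyl on the saturated ring carbon (a number 8.8 percentage points lower from compound 2 to compound 4 (within the scatter)). This position therefore accepts a 3,4-dimethoxyphenyl group of 10 heavy atoms, and that group still reads beyond the scatter against 2-chlorophenyl (a number 23.3 percentage points higher from compound 3 to compound 4 (beyond the scatter)). No measurement here accounts for these differences.

Open, from the compounds shown here alone, is whether the 2-chlorophenyl loss comes with chlorine itself or with its place on the ring, which 4-chlorophenyl would test. Also open, going by these compounds, is how an amine or a carboxylic acid on this phenyl ring would read.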